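The source may hold more compounds than are shown below. What is called first, only, known or untested is meant among the compounds shown, and "the series" means these compounds.

Measured compounds:
compound 1, `CC(C)(COC(=O)[C@@H](N)c1ccccc1)COC1(c2ccc(Cl)cc2)c2ccccc2C(=O)N1Cc1ccccc1`: 44000 nM
compound 2, `CC(=O)OCCCOC1(c2ccc(Cl)cc2)c2ccccc2C(=O)N1Cc1ccc(Cl)cc1`: 68000 nM
compound 3, `CC(C)(CO)COC1(c2ccc(Cl)cc2)c2ccccc2C(=O)N1Cc1ccc(Cl)cc1`: 65000 nM

In a functional assay on HCT-116 cells (Homo sapiens) for inhibition, read by fluorescence, with a stated time of 48 h (a lower number here means a stronger inhibitor of growth, a higher number a weaker inhibitor of growth), compound 3 gives 65000 nM, the second highest of the three numbers, though within the scatter of both compound 2 and compound 1. Compound 4, `CC(C)(COC(=O)[C@@H](N)c1ccccc1)COC1(c2ccc(Cl)cc2)c2ccccc2C(=O)N1Cc1ccc(Cl)cc1`, is not yet measured; the change from compound 3 is (amino(phenyl)methyl)carbonyl in place of hydrogen on an oxygen on a saturated carbon. Going by the values given here, the one step already measured at this end of the chain, a 1.0-fold lower number from compound 2 to compound 3 (0.02 log units; within the scatter), exchanged one chain end for another and left the number essentially where it was. Compound 1 carries the same ester as compound 4 and differs from it only by a single chlorine atom on the core; in this assay compound 1 gives 44000 nM, a number within the scatter of compound 3. Taken together, the step of a 1.4-fold lower number from compound 3 to compound 4 (0.16 log units; within the scatter) is expected to be small, at most a modest move toward a lower number, not clearly beyond the scatter. Compound 4 is therefore estimated at 45000 nM, with a range of 20000 nM to 100000 nM.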

Compound 4, concentration for 50% growth inhibition: 38000 nM
Compound 4: the middle estimate sits 1.2-fold (0.07 log units) above what was measured; measured number inside the range.
By their numbers in this assay, from the lowest: compounds 4, 1, 3 and 2 (each within the scatter of the next).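

In this assay the change from hydroxy to ((amino(phenyl)methyl)carbonyl)oxy gives a 1.7-fold lower number from compound 3 to compound 4 (0.23 log units; within the scatter) and so shows that a group with its own aromatic ring and a defined stereocentre can sit on this oxygen without moving the number beyond the scatter. The chloro in place of hydrogen on an aromatic carbon, read here with this ester present, gives a 1.2-fold lower number from compound 1 to compound 4 (0.06 log units; within the scatter) and also stays within the scatter. No measured information is available to explain either result.

As far as these compounds go, whether an amine or a carboxylic acid in place of the hydroxy, or a longer chain on this oxygen, would produce a step beyond the scatter remains open. Also open, from the compounds shown here alone, is whether the ester with the opposite arrangement at its stereocentre would give a number close to these.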